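Swapping an amide group at the assay limit

The source may hold more compounds than are shown below. What is called first, only, known or untested is meant among the compounds shown, and "the series" means these compounds.

Results so far in a functional assay on HCT-116 cells (Homo sapiens) for antiproliferative activity, read by MTT assay, with a stated time of 72 h (a higher number here means a weaker inhibitor, a lower number a stronger inhibitor), are these.
Compound 1 `O=C(CCc1cccc2c1B(O)OC2)NCc1ccccc1` gives > 100000 nM as a limit of the assay.
Compound 2 `O=C(CCc1cccc2c1B(O)OC2)Nc1nccs1` gives > 100000 nM as a limit of the assay.

Compound 2 therefore has no true number, only a limit, and the same holds for the other measured compound (the limit of > 100000 nM in this assay, at which 2 of the 2 values shown sit). Compound 3 `O=C(CCc1cccc2c1B(O)OC2)Nc1ccc(F)cc1` keeps the shared core and carries 4-fluorophenyl in place of 1,3-thiazol-2-yl on an amide-type nitrogen. For the measured compounds named here, the one measured step at this nitrogen (a step that the two limits leave unreadable from compound 1 to compound 2) bears on the change, but it has no readable size and gives no direction. No step beyond the usual scatter is therefore expected in this assay and another limit is likely. The expected step is a number no higher from compound 2 to compound 3 (the limit leaves the size open) as a rough estimate. For compound 3 the estimated value is 100000 nM with an expected range from 30000 nM to 200000 nM in this weak region.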

Compound 3, half-maximal inhibitory concentration: 650 nM
The estimate for compound 3 lay 150-fold (2.19 log units) above the measured number; the whole stated range lies above it.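

In this assay, the group on the amide-type nitrogen turns out to decide whether a compound gives a true number at all. Putting 4-fluorophenyl in place of 1,3-thiazol-2-yl gives an at least 150-fold lower number from compound 2 to compound 3 (2.18 log units; beyond the scatter), and putting it in place of benzyl gives an at least 150-fold lower number from compound 1 to compound 3 (2.18 log units; beyond the scatter). The earlier pair gave no direction at this position, whereas compound 3 is the only compound here with a true number and not a limit: the limit of > 100000 nM in this assay, at which 2 of the 3 values shown sit.

The compounds shown leave open whether the fluorine or the carbon-only ring carries this step, and a plain phenyl group on the same nitrogen would separate the two. Going by these compounds, how other groups there, such as a pyridine ring or a cyclohexyl group, would read in this assay also remains open.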